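Notes on replacing the methylselenyl group of compound 2

The compounds below may be only part of what the source reports. "The series", "measured", "known", "first", "only" and "open" are said of these compounds alone.

Measured so far:
compound 1 `CCCCCSc1nc(NCc2ccc([Se]C)cc2)c2ccccc2n1`: 13000 nM
compound 2 `CSc1nc(NCc2ccc([Se]C)cc2)c2ccccc2n1`: 36400 nM

In a functional assay on MCF7 cells (Homo sapiens) for cytotoxicity, read by MTT assay, with a stated time of 72 h (on this read-out lower numbers stand for stronger inhibition of growth and higher numbers for weaker inhibition of growth), compound 2 gives 36400 nM, the highest of the two numbers. Compound 1 gives 13000 nM. Among the measured compounds shown here, the only measured step is a 2.8-fold higher number from compound 1 to compound 2 (0.45 log units; beyond the scatter), and it concerns the chain on sulfur, not the aromatic ring. Compound 3 `CSc1nc(NCc2ccccc2)c2ccccc2n1` differs from compound 2 by a hydrogen atom in place of a group of 2 heavy atoms (1 carbon, 1 selenium; no ring), on an aromatic carbon. For the measured compounds named here, no measured step bears on this change, so the expectation rests on compound 2 alone. For compound 3 the expected step is a 1.5-fold higher number from compound 2 to compound 3 (0.18 log units; within the scatter), a weakening that may not exceed the scatter. Compound 3 is estimated at 55000 nM, within 18000 nM to 170000 nM.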

Compound 3, concentration for 50% growth inhibition: 41500 nM
Compound 3: middle estimate off by 1.3-fold (0.12 log units), on the high side; measured number inside the range.
By their numbers in this assay, from the lowest: compound 1; then compounds 2 and 3 (each within the scatter of the next).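

In this assay, hydrogen in place of the methylselenyl group on the aromatic carbon gives a 1.1-fold higher number from compound 2 to compound 3 (0.06 log units; within the scatter) and so leaves the number within the scatter. With the short chain on sulfur, this group therefore makes no readable difference at this position, whereas the earlier step showed only a change at the chain on sulfur. As far as these compounds go, whether an amine or a carboxylic acid at this position would read the same stays open, as does the same change with the longer sulfur chain of compound 1. No measurement at hand bears on why this change leaves the number in place.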